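Pyridazin-4-yl in Place of Pyrimidin-5-yl on Compound 1

The compounds below may be only part of what the source reports. "The series", "measured", "known", "first", "only" and "open" are said of these compounds alone.

In an ADME assay on brain (Rattus norvegicus) for protein binding (on this read-out higher numbers stand for a larger free fraction and lower numbers for a smaller free fraction), compound 1 (`O=C1O[C@]2(CC[C@H](CNc3cnn(-c4ccccc4F)c3)CC2)CN1c1cncnc1`) gives 0.044. Compound 2 (`Cc1ccccc1-c1ccc(NC[C@H]2CC[C@]3(CC2)CN(c2cccnn2)C(=O)O3)nn1`) gives 0.051, and the two values lie within the scatter of each other. Among the measured compounds shown here, compound 1 therefore cannot be separated from the only other measured compound on this read-out.

Compound 3 (`O=C1O[C@]2(CC[C@H](CNc3cnn(-c4ccccc4F)c3)CC2)CN1c1ccnnc1`) is still to be measured. It keeps the core of compound 1 and carries pyridazin-4-yl in place of pyrimidin-5-yl on an amide-type nitrogen in a ring. The two groups have the same atoms, joined differently.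

For the measured compounds named here, no pair of measured compounds differs in one place only, so the data hold no direct precedent for this swap. Going by the values given here, the only guide is the narrow spread of the measured values, with compound 1 at 0.044 and compound 2 at 0.051, although two compounds are a thin basis. A small rise is expected, and the estimated change, a 1.3-fold higher number from compound 1 to compound 3 (0.10 log units; within the scatter), is not expected to go beyond the scatter. Compound 3 is therefore estimated at 0.055, with an expected range from 0.03 to 0.1.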

Compound 3, unbound fraction: 0.044
Compound 3: middle estimate off by 1.3-fold (0.10 log units), on the high side; low and high end bracket the measured number.
By their numbers in this assay, from the lowest: compounds 1, 3 and 2 (each within the scatter of the next).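

In this assay, among the compounds shown here, putting pyridazin-4-yl in place of pyrimidin-5-yl on the amide-type nitrogen in a ring gives no change at the digits printed from compound 1 to compound 3 (within the scatter) and this is the first pair in the set to differ in one place only. For the compounds shown here, it therefore supplies the direct comparison that the earlier compounds lacked: with the rest of compound 1 held constant, this read-out does not separate these two groups, which have the same atoms joined differently. No measurement available here offers an explanation for this result.

The compounds shown leave open whether a group with different atoms on this nitrogen, such as a phenyl ring, a carboxylic acid or a longer chain ending in an amine, would give a step beyond the scatter in this assay rather than one within it. They also leave open whether pyridazin-4-yl and pyrimidin-5-yl would remain indistinguishable on this read-out if another part of compound 1 were different as well.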